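Notes on the step from compound 2 to compound 4

This account rests on a few compounds, and the source may have more. Where it says the series, first, only, none or still open, it means among the compounds named here.

compound 1 `CCc1ccc(SCc2ccc(/C=C/C(=O)Nc3ccccc3N)cc2)cc1`: 3.29%
compound 2 `CCc1ccc(SCc2ccc(C(=O)Nc3ccccc3N)cc2)cc1`: 40.7%
compound 3 `Cc1ccc(SCc2ccc(/C=C/C(=O)Nc3ccccc3N)cc2)cc1`: 6.23%

In a functional assay on HCT-116 cells (Homo sapiens) for inhibition, read by CCK-8 assay, with a stated time of 72 h, tested at 2 uM (a higher number here means more inhibition of growth at the concentration tested, a lower number less inhibition of growth), compound 2 stands highest of the three, beyond the scatter from both compound 1 and compound 3. Compound 4 `Cc1ccc(SCc2ccc(C(=O)Nc3ccccc3N)cc2)cc1` is not yet measured. It differs from compound 2 by hydrogen in place of methyl on a saturated chain carbon bound to an aromatic carbon, which reads as ethyl to methyl. Going by the values given here, one measured step bears on this change: a number 2.9 percentage points higher from compound 1 to compound 3 (within the scatter). That step has the same change on a different core, and both of its values lie far under that of compound 2, so it is only a limited guide. The expected step is a number 0.7 percentage points lower from compound 2 to compound 4 (within the scatter), with none expected beyond the scatter. Compound 4 is estimated at 40%, within a range of 26% to 54%.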

Compound 4, percent growth inhibition at one concentration: 74.8%
Compound 4: the middle estimate sits 34.8 percentage points below what was measured; the whole stated range lies below it.
By their numbers in this assay, from the lowest: compounds 1 and 3 (each within the scatter of the next); then compound 2; then compound 4.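

In this assay, the change from 4-ethylphenyl to 4-methylphenyl is far from neutral on the core of compound 2, giving a number 34.1 percentage points higher from compound 2 to compound 4 (beyond the scatter). The earlier pair on the core of compound 1 gave no sign of this, so the size of the step depends on the core that carries it: the same change on two cores in this assay, a number 2.9 percentage points higher (within the scatter) from compound 1 to compound 3 and a number 34.1 percentage points higher (beyond the scatter) from compound 2 to compound 4, 31.2 percentage points apart, beyond the scatter of two such steps

The compounds shown carry only ethyl and methyl here, so how a propyl chain or a methoxy group would read on the core of compound 2 stays open. As far as these compounds go, what makes the same change count on one core and not on the other also stays open.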